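A few compounds are considered here, and "the series" means these few. Any claim that something is new, unique, unknown or untested is made for them only; others in the source may bear on it.

Measured so far in a physicochemical assay for lipophilicity, at pH 7.4; a lower number here means a more polar compound, a higher number a more lipophilic compound
compound 1 `CNC(=O)c1cc(C(=O)N[C@H]2[C@@H]3COC[C@@H]32)cc2c1OC[C@H]2c1ccccc1` gives 3.3
compound 2 `CNC(=O)c1cc(C(=O)N[C@H]2[C@@H]3COC[C@@H]32)cc2c1OC[C@H]2c1ccncc1` gives 1.3
compound 3 `CNC(=O)c1cc(C(=O)N[C@H]2[C@@H]3COC[C@@H]32)cc2c1OC[C@H]2c1ccc(F)cc1` gives 3.6

Compound 3 stands at 3.6, within the scatter of compound 1 , so these two values cannot be ordered. Compound 2 lies clearly apart from both.

The next compound is compound 4 `CNC(=O)c1cc(C(=O)N[C@H]2[C@@H]3COC[C@@H]32)cc2c1OC[C@H]2c1ccccc1C`, with 2-methylphenyl in place of 4-fluorophenyl on a saturated ring carbon, two ring bonds from the ring oxygen: 2-methylphenyl in place of 4-fluorophenyl on a saturated ring carbon.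

Two measured steps at this position are large, a number 2.00 log units lower from compound 1 to compound 2 (beyond the scatter) and a number 2.30 log units higher from compound 2 to compound 3 (beyond the scatter), but both involve pyridin-4-yl, which plays no part in the present change. The closer guide is a number 0.30 log units higher from compound 1 to compound 3 (within the scatter), which joins the two compounds whose aromatic group has a ring of carbon only, as compound 4 also has. For the measured compounds named here, no measured compound carries a methyl group on that ring, so this part of the change has no direct data behind it.

On that guide, no step beyond the scatter is expected, and the estimate is a number 0.10 log units higher from compound 3 to compound 4 (within the scatter). For compound 4 the estimated value is 3.7, with an expected range from 3.3 to 4.1.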

Compound 4, distribution coefficient: 4
The estimate for compound 4 lay 0.30 log units below the measured number; measured number inside the range.
By their numbers in this assay, from the lowest: compound 2; then compounds 1 and 3 (each within the scatter of the next); then compound 4.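

In this assay, the carbon-only aromatic groups on this saturated ring carbon now separate: the change to 2-methylphenyl gives a number 0.40 log units higher from compound 3 to compound 4 (beyond the scatter) and, against the unsubstituted phenyl, a number 0.70 log units higher from compound 1 to compound 4 (beyond the scatter), whereas the fluoro change gave only a number 0.30 log units higher from compound 1 to compound 3 (within the scatter). Compound 4 is therefore the highest of the four compounds, and the step from the pyridin-4-yl compound widens to a number 2.70 log units higher from compound 2 to compound 4 (beyond the scatter), so replacing hydrogen on this aromatic ring can move the number beyond the scatter, though only the methyl case among the two substituted rings does so. No available measurement explains why the methyl and fluoro changes differ at this position.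

Moving from 4-fluorophenyl to 2-methylphenyl changes both the substituent and its place on the ring, so the compounds shown cannot separate these two contributions. For the compounds shown here, it also remains open how this position would respond to an aromatic ring carrying a carboxylic acid, an amine or a longer alkyl chain, since the present substituted rings carry only a single fluoro or methyl group.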